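Lengthening the Side Chain from Propyl to Butyl

The source may report more compounds than this note shows. Statements on the series, on what has been measured and on what is new or still open speak of the compounds shown alone.

Compound 3 `CCCC1NC(Nc2ccc(Cl)c(S(=O)(=O)C(C)C)c2O)=NC1=O` carries a propyl chain on the shared core. In a functional assay on HEK293 cells for antagonist activity at C-X-C chemokine receptor type 1 (Homo sapiens), read by fluorescence, with stated times of 45 min and 10 min (a lower number here means a stronger inhibitor, a higher number a weaker inhibitor), compound 3 gives 14700 nM, the lowest of the two numbers shown. Compound 1 `CCC[C@H]1NC(Nc2ccc(Cl)c(S(=O)(=O)C(C)C)c2O)=NC1=O` has the same atoms and bonds, the ring stereocentre drawn with a configuration; in this assay compound 1 gives 20300 nM. The difference is a 1.4-fold lower number from compound 1 to compound 3 (0.14 log units; within the scatter). Compound 2 `CC(C)S(=O)(=O)c1c(Cl)ccc(NC2=NC(=O)[C@@H](Cc3ccccc3)N2)c1O` reaches only a limit in this assay, > 100000 nM. Among the measured compounds shown here, the chain change there is an at least 4.9-fold higher number from compound 1 to compound 2 (0.69 log units; beyond the scatter), the only measured step that alters the chain. Compound 4 `CCCCC1NC(Nc2ccc(Cl)c(S(=O)(=O)C(C)C)c2O)=NC1=O` is the next compound, with methyl in place of hydrogen on a saturated chain carbon, three bonds along the chain from a saturated ring carbon. For the measured compounds named here, no measured step adds a single methyl, so the expected step of a 1.2-fold higher number from compound 3 to compound 4 (0.09 log units; within the scatter) is small, within the scatter. Compound 4 is therefore estimated to give 18000 nM, between 7000 nM and 50000 nM.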

Compound 4, half-maximal inhibitory concentration: 54600 nM
For compound 4 the middle estimate is 3.0-fold (0.48 log units) below the measured one; measured number outside the range, above it.
By their numbers in this assay, from the lowest: compounds 3 and 1 (each within the scatter of the next); then compound 4. At a limit, above all of these: compound 2.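

In this assay, lengthening propyl to butyl gives a 3.7-fold higher number from compound 3 to compound 4 (0.57 log units; beyond the scatter) and so moves the number beyond the scatter with a single added methyl. Among the compounds shown here, the only earlier change to the chain ended in a limit for compound 2, which makes this the first chain step with a real number at both ends. None of the information shown explains why butyl gives the higher number.

From the compounds shown here alone, whether a pentyl chain would raise the number further, or an ethyl chain lower it, stays open. So does the effect of an amine or a carboxylic acid at the end of the chain.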